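Benzyl for 4-methoxyphenyl on the ring nitrogen of compound 1

A few compounds are considered here, and "the series" means these few. Any claim that something is new, unique, unknown or untested is made for them only; others in the source may bear on it.

Compound 1, `COc1ccc(N2CCN(C(=S)SCc3ccc(C(=O)Nc4ccccc4N)cc3)CC2)cc1`, gives 28.1% in a functional assay on A-375 cells (Homo sapiens) for antiproliferative activity, read by CCK-8 assay, with a stated time of 72 h, tested at 2 uM; a higher number here means a stronger effect of the compound at the concentration tested, a lower number a weaker effect. Compound 2, `Nc1ccccc1NC(=O)c1ccc(CSC(=S)N2CCCc3ccccc32)cc1`, gives 26.5%. Compound 3, `Nc1ccccc1NC(=O)c1ccc(CSC(=S)N2CCCC2)cc1`, gives 30.2%.

Compound 1 stands second highest of the three numbers, within the scatter of both compound 2 and compound 3. Compound 4, `Nc1ccccc1NC(=O)c1ccc(CSC(=S)N2CCN(Cc3ccccc3)CC2)cc1`, differs from compound 1 by benzyl in place of 4-methoxyphenyl on an amine nitrogen in a ring. Going by the values given here, the one measured step, a number 3.7 percentage points higher from compound 2 to compound 3 (within the scatter), concerns the thiocarbonyl carbon, not the amine nitrogen in a ring, so no step bears directly on this change; it shows only that varying the group on the thiocarbonyl carbon left the read-out within the scatter. Compound 4 is therefore expected to show no step beyond the scatter, a number 0.1 percentage points lower from compound 1 to compound 4 (within the scatter), and its estimate is 28%, between 17% and 40%.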

Compound 4, a percentage reported as inhibition, at one concentration (the size of the read-out at that concentration, not a potency): 10.6%
Compound 4: the middle estimate sits 17.4 percentage points above what was measured; measured number outside the range, below it.
By their numbers in this assay, from the lowest: compound 4; then compounds 2, 1 and 3 (each within the scatter of the next).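

Going by these compounds alone, on the amine nitrogen in a ring, benzyl in place of 4-methoxyphenyl gives a number 17.5 percentage points lower from compound 1 to compound 4 (beyond the scatter) and is the first step here to leave the scatter. This position therefore responds to its group, whereas the change on the thiocarbonyl carbon, a number 3.7 percentage points higher from compound 2 to compound 3 (within the scatter), stayed within the scatter. Nothing shown here gives a reason for the step.

The compounds shown leave open whether the step follows the loss of the methoxy group or the change from phenyl to benzyl. A plain phenyl or a 4-methoxybenzyl group on that nitrogen would separate the two.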